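The compounds below may be only part of what the source reports. "The series", "measured", "known", "first", "only" and "open" are said of these compounds alone.

Three compounds built on one shared core have numbers in a functional assay on MCF7 cells (Homo sapiens) for antiproliferative activity, read by MTT assay, with a stated time of 48 h; on this read-out lower numbers stand for stronger inhibition and higher numbers for weaker inhibition. There, compound 1 `Cc1ccc(NCc2cn(-c3ccccc3)nc2-c2ccc(Cl)cc2)cc1` gives 3110 nM, compound 2 `Fc1ccc(NCc2cn(-c3ccccc3)nc2-c2ccc(Cl)cc2)cc1` gives 1880 nM and compound 3 `Cc1ccc(-c2nn(-c3ccccc3)cc2CNc2ccc(F)cc2)cc1` gives 5880 nM. Compound 2 therefore stands within the scatter of compound 1 and clearly apart from compound 3.

The next compound, compound 4 `Clc1ccc(-c2nn(-c3ccccc3)cc2CNc2ccc(Br)cc2)cc1`, has not yet been measured. It differs from compound 2 in a single group: bromo in place of fluoro on an aromatic carbon. Put another way, 4-fluorophenyl becomes 4-bromophenyl, with bromo in place of fluoro on an aromatic carbon.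

Two measured steps offer guidance. The more relevant one changes the same place, where fluoro in place of methyl gave a 1.7-fold lower number from compound 1 to compound 2 (0.22 log units; within the scatter). The other, methyl in place of chloro, gave a 3.1-fold higher number from compound 2 to compound 3 (0.50 log units; beyond the scatter), but it lies at a different place in the molecule and so says less about this swap. Among the compounds with values here, no measured compound carries bromo, so the evidence is indirect. With only the same-place step as a guide, no change beyond the scatter is expected in this assay, and the estimated move is a 1.2-fold higher number from compound 2 to compound 4 (0.07 log units; within the scatter). For compound 4 the expected value is 2200 nM, within an estimated range from 900 nM to 5500 nM.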

Compound 4, half-maximal inhibitory concentration: 2620 nM
Compound 4: middle estimate off by 1.2-fold (0.08 log units), on the low side; low and high end bracket the measured number.
By their numbers in this assay, from the lowest: compounds 2, 4, 1 and 3 (each within the scatter of the next, the first and the last beyond it).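

In this assay, replacing the fluoro of the 4-fluorophenyl group with bromo gives a 1.4-fold higher number from compound 2 to compound 4 (0.14 log units; within the scatter), and bromo in place of methyl at the same place gives a 1.2-fold lower number from compound 1 to compound 4 (0.07 log units; within the scatter). Before this result, this position rested on a single step between methyl and fluoro; now a second halogen has been added, and all three pairings among methyl, fluoro and bromo stay within the scatter, so compounds 1, 2 and 4 show no measurable preference among these three groups in this assay. Nothing available here offers an explanation for this lack of separation at the position.

As far as these compounds go, it remains open whether a different kind of group at this position, such as an amine, a carboxylic acid or a methoxy group, would move the number beyond the scatter. Within the data shown here, it is also open whether the swap from fluoro to bromo would read the same with methyl instead of chloro at the other place that varies, the one where the step from compound 2 to compound 3 went beyond the scatter.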